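The source may hold more compounds than are shown below. What is called first, only, known or untested is meant among the compounds shown, and "the series" means these compounds.

Compound 1, `O=C1Nc2cc(Cl)c(F)cc2/C1=N/NC(=S)Nc1ccc(Cl)cc1`, and compound 2, `Cc1ccc(NC(=S)N/N=C2\C(=O)Nc3cc(Cl)c(F)cc32)cc1`, share one core. In a functional assay on CCRF-CEM cells (Homo sapiens), with a stated time of 72 h (a higher number here means a weaker inhibitor, a lower number a stronger inhibitor), compound 1 gives 48000 nM, and compound 2 gives 132000 nM. The difference between them is methyl in place of chloro on an aromatic carbon, and that change made a 2.8-fold higher number from compound 1 to compound 2 (0.44 log units; beyond the scatter).

Compound 3, `O=C1/C(=N\NC(=S)Nc2ccc(Cl)cc2)c2cc(Br)ccc2N1Cc1ccc(F)cc1`, is built on a different core; the difference between the two cores is not broken down here. In this assay compound 3 gives 61000 nM, which sits within the usual scatter of compound 1 and is a lower number than compound 2.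

Compound 4, `Cc1ccc(NC(=S)N/N=C2\C(=O)N(Cc3ccc(F)cc3)c3ccc(Br)cc32)cc1`, has not yet been measured. It differs from compound 3 by methyl in place of chloro on an aromatic carbon, the same change that separates compound 1 from compound 2, at the same kind of place. Because that change gave a 2.8-fold higher number from compound 1 to compound 2 (0.44 log units; beyond the scatter), a step of about the same size, a 2.6-fold higher number from compound 3 to compound 4 (0.42 log units; beyond the scatter), is expected from compound 3 to compound 4. Compound 4 is therefore estimated to give 160000 nM in this assay, most likely between 60000 nM and 400000 nM.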

Compound 4, half-maximal inhibitory concentration: 132000 nM
Compound 4: the middle estimate sits 1.2-fold (0.08 log units) above what was measured, within the range that was stated.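

In this assay, exchanging 4-chlorophenyl for 4-methylphenyl on the core of compound 3 gave a 2.2-fold higher number from compound 3 to compound 4 (0.34 log units; beyond the scatter), a rise in the same direction as on the core of compound 1. Set side by side, the two steps cannot be told apart: the same change on two cores in this assay, a 2.8-fold higher number (0.44 log units; beyond the scatter) from compound 1 to compound 2 and a 2.2-fold higher number (0.34 log units; beyond the scatter) from compound 3 to compound 4, 1.3-fold (0.10 log units) apart, within the scatter of two such steps

So in these two pairs, the change carried over from one core to the other with about the same size, which is what made the earlier step useful as a guide; two pairs, however, do not establish a rule for other cores, and they do not explain why the number rises when methyl replaces chloro.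

As far as these compounds go, it remains open whether other groups in that place, such as a methoxy group, an amine or a carboxylic acid, would raise or lower the number. From the compounds shown here alone, it is also open whether the same step would appear on a third core, or in a test on a different kind of cell.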